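A methylphenyl returns to the ring nitrogen

The source may hold more compounds than are shown below. What is called first, only, known or untested is meant among the compounds shown, and "the series" means these compounds.

Compound 3 `CCCn1c(=O)[nH]c2nc(-c3ccc(S(=O)(=O)N4CCN(C(C)c5ccccc5)CC4)cc3)[nH]c2c1=O` stands lowest of the three measured compounds in an assay on CHO cells for displacement of a labelled ligand from adenosine receptor A3 (Homo sapiens), read by scintillation counting, with a stated time of 45 min, tested at 1 uM, in the presence of a further agent that is not named here (a higher number here means more inhibition at the concentration tested (going by the name of the read-out), a lower number less inhibition), giving 0%. Compound 2 `CCCn1c(=O)[nH]c2nc(-c3ccc(S(=O)(=O)N4CCN(Cc5ccc(Br)c(F)c5)CC4)cc3)[nH]c2c1=O` gives 27% and compound 1 `CCCn1c(=O)[nH]c2nc(-c3ccc(S(=O)(=O)N4CCN(c5cccc(F)c5)CC4)cc3)[nH]c2c1=O` gives 44%. Compound 4 `CCCn1c(=O)[nH]c2nc(-c3ccc(S(=O)(=O)N4CCN(c5ccc(C)cc5)CC4)cc3)[nH]c2c1=O` differs from compound 3 by 4-methylphenyl in place of 1-phenylethyl on an amine nitrogen in a ring. Within the data shown here, two measured steps bear on this change, both running the other way: a number 44 percentage points lower from compound 1 to compound 3 (beyond the scatter) was large and a number 27 percentage points lower from compound 2 to compound 3 (beyond the scatter) was modest. Because a number 44 percentage points lower from compound 1 to compound 3 (beyond the scatter) accompanied the move from 3-fluorophenyl, held directly on the ring nitrogen, to 1-phenylethyl, putting 4-methylphenyl directly on that nitrogen in compound 4 is expected to raise the number by a large step, a number 35 percentage points higher from compound 3 to compound 4 (beyond the scatter). Compound 4 is therefore estimated at 35%, with a range from 10% to 60%.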

Compound 4, a percentage reported as inhibition, at one concentration (the size of the read-out at that concentration, not a potency): 25%
Compound 4: middle estimate off by 10 percentage points, on the high side; low and high end bracket the measured number.
By their numbers in this assay, from the lowest: compound 3; then compounds 4 and 2 (each within the scatter of the next); then compound 1.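

In this assay the step of a number 19 percentage points lower from compound 1 to compound 4 (beyond the scatter) shows that a phenyl ring held directly on the amine nitrogen in a ring does not fix the number, since 3-fluorophenyl and 4-methylphenyl give different results there. The step of a number 25 percentage points higher from compound 3 to compound 4 (beyond the scatter) shows that 4-methylphenyl recovers only part of what 1-phenylethyl lost. The step of a number 2 percentage points lower from compound 2 to compound 4 (within the scatter) separates 4-methylphenyl from the 4-bromo-3-fluorobenzyl group by no more than the scatter, so directly attached and benzyl groups cannot be ranked from this pair.

No evidence here explains these differences. Going by these compounds, whether an amine or a carboxylic acid in place of the methyl of 4-methylphenyl would change the number remains open.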